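The source may hold more compounds than are shown below. What is called first, only, known or untested is meant among the compounds shown, and "the series" means these compounds.

Two compounds measured in an ADME assay for permeability, using PAMPA, with a stated time of 30 min, at pH 7.4 (on this read-out lower numbers stand for lower permeability and higher numbers for higher permeability), frame this step. Compound 1 `CC(C)Cc1ccc2c(NCCCNCc3ccco3)ccnc2c1` carries an isobutyl group on the shared core; in this assay compound 1 gives 23 10^-6 cm/s. Compound 2 `c1coc(CNCCCNc2ccnc3cc(-c4cccc5ccccc45)ccc23)c1` differs at one place only, and in this assay compound 2 gives 237 10^-6 cm/s. For the measured compounds named here, that single change produced a 10-fold higher number from compound 1 to compound 2 (1.01 log units; beyond the scatter), so compound 2 stands highest of the two numbers known, with compound 1 the nearest and well below it.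

The next compound, compound 3 `N#Cc1ccc(Cc2ccc3c(NCCCNCc4ccco4)ccnc3c2)cc1`, changes the same place on the shared core once more: 4-cyanobenzyl in place of naphthalen-1-yl on an aromatic carbon.

Going by the values given here, only one measured step speaks to this position, and it was large, namely a 10-fold higher number from compound 1 to compound 2 (1.01 log units; beyond the scatter). It shows that exchanging the group at this place can move the read-out far. Since the naphthalen-1-yl group that brought the high number now leaves, the expected direction is downward, and the expected size is a 5.9-fold lower number from compound 2 to compound 3 (0.77 log units; beyond the scatter), roughly undoing the earlier rise because compound 1 without that group gave 23 10^-6 cm/s. Compound 3 is therefore estimated at 40 10^-6 cm/s, within a range from 12 10^-6 cm/s to 130 10^-6 cm/s.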

Compound 3, apparent permeability: 23 10^-6 cm/s
Estimate against measurement, compound 3: 1.7-fold (0.24 log units) above, and the stated range covers the measured number.
By their numbers in this assay, from the lowest: compounds 1 and 3 (each within the scatter of the next); then compound 2.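

In this assay the exchange of naphthalen-1-yl for 4-cyanobenzyl removes the whole of the earlier rise (a 10-fold lower number from compound 2 to compound 3 (1.01 log units; beyond the scatter)), and compound 3 matches compound 1 even though their groups differ by 4-cyanophenyl in place of isopropyl on a saturated chain carbon bound to an aromatic carbon (no change at the digits printed from compound 1 to compound 3 (within the scatter)). So among these three compounds the high number stands with naphthalen-1-yl alone, and the two quite different groups of compound 1 and compound 3 give the same low number. Heavy-atom count does not follow the read-out here, since 4-cyanobenzyl and naphthalen-1-yl are close in heavy atoms; what does separate them is one six-membered aromatic ring against two, together with the nitrile and its saturated carbon.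

Which of those differences matters stays open, and a plain benzyl group, a phenyl group or naphthalen-2-yl at this place would help pull them apart. Nothing given here offers a reason for the size of these steps.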